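Lipophilicity notes: propanoyl to (pyridin-2-yl)carbonyl

The source may hold more compounds than are shown below. What is called first, only, known or untested is meant among the compounds shown, and "the series" means these compounds.

Measured so far in a physicochemical assay for lipophilicity, read by HPLC, measured as chromatographic lipophilicity, at pH 7.4 (on this read-out lower numbers stand for lower lipophilicity and higher numbers for higher lipophilicity), for this series
- Compound 1 `O=C(c1cccnc1)N1N=CCC1c1ccccc1` gives 2.7
- Compound 2 `CCC(=O)N1CCC(C(=O)N2N=CCC2c2ccccc2)CC1` gives 3.2

Compound 2 is the higher of the two, and its gap to compound 1 lies beyond the scatter. The next compound, compound 3 `O=C(c1ccccn1)N1CCC(C(=O)N2N=CCC2c2ccccc2)CC1`, has pyridin-2-yl in place of ethyl on a carbonyl carbon. Among the compounds with values here, no measured pair isolates this change, so the expectation rests on the structural change alone. A small upward step, not beyond the scatter, is expected in this assay (a number 0.20 log units higher from compound 2 to compound 3 (within the scatter)). Compound 3 is estimated at 3.4 with an expected range from 3 to 3.8 on this scale.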

Compound 3, distribution coefficient: 3.1
Compound 3: middle estimate off by 0.30 log units, on the high side; low and high end bracket the measured number.
By their numbers in this assay, from the lowest: compound 1; then compounds 3 and 2 (each within the scatter of the next).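

In this assay, within the data shown here, pyridin-2-yl in place of ethyl on a carbonyl carbon gives a number 0.10 log units lower from compound 2 to compound 3 (within the scatter), the first measured pair to isolate a change at this position. A six-membered aromatic ring with a hydrogen-bond acceptor and a small ethyl group therefore cannot be told apart on this read-out here. No supporting data explain this result.

On these data alone, whether this holds for other groups on the same carbonyl carbon stays open. Phenyl, a longer chain and an amine remain the obvious untested cases among the compounds shown.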